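The compounds below may be only part of what the source reports. "The series", "measured", "known", "first", "only" and "open" are said of these compounds alone.

Measured compounds, in a functional assay on HCT-116 cells (Homo sapiens) for cytotoxicity, read by MTT assay, with a stated time of 72 h; a higher number here means a weaker inhibitor, a lower number a stronger inhibitor:
- compound 1 `O=C(NCc1ccc(F)cc1)c1nc(Br)c2cccnc2c1NCCCNc1c(C(=O)NCc2ccc(F)cc2)nc(Br)c2cccnc12`: > 20000 nM
- compound 2 `C[C@@H](Nc1c(C(=O)NCc2ccc(F)cc2)nc(Br)c2cccnc12)c1ccccc1`: > 20000 nM
- compound 3 `N[C@H]1CC[C@H](Nc2c(C(=O)NCc3ccc(Oc4ccccc4)cc3)nc(Br)c3cccnc23)CC1`: "not determined" (no result reported)

Compound 2 gives > 20000 nM, which is a limit of the assay and not a number. Its standing in the series is the limit of > 20000 nM in this assay, at which 2 of the 3 values shown sit. For the measured compounds named here, no numerical value exists yet in this set, and no step between measured compounds is available to size a change.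

Compound 4 `CN(C)CCCNc1c(C(=O)NCc2ccc(F)cc2)nc(Br)c2cccnc12` has 3-(dimethylamino)propyl in place of 1-phenylethyl on a nitrogen on an aromatic ring, and the count of the change reads (3-(dimethylamino)propyl in place of 1-phenylethyl on a nitrogen on an aromatic ring).

With only limits as a reference, the expectation is loose. The expected change is an at least 1.6-fold lower number from compound 2 to compound 4 (0.22 log units; that floor lies within the scatter), in the direction of stronger inhibition in this assay. A result at the same limit remains about as likely as a measurable number. For compound 4 the estimated value is 12000 nM, with an expected range from 3000 nM to 30000 nM.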

Compound 4, half-maximal inhibitory concentration: > 10000 nM
Compound 4 gave a limit, no number; the forecaster's own chance of this, stated with the estimate: 50%; the middle value lies beyond the limit too.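

In this assay, for the compounds shown here, compound 2 and compound 4 both give limits of the assay and not numbers, and no step between them can be read. The compounds shown leave open whether exchanging 1-phenylethyl for 3-(dimethylamino)propyl changes the value in this assay at all.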